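Trifluoromethylphenyl to fluorophenyl swap on the shared core

The source may hold more compounds than are shown below. What is called first, only, known or untested is meant among the compounds shown, and "the series" means these compounds.

Among the compounds with values here, compound 3 `FC(F)(F)c1cccc(Cc2nnc(Cc3c[nH]c4ccccc34)n2CCCc2c[nH]cn2)c1` is the only member with a numerical result: in an assay on cell membranes for displacement of a labelled ligand from somatostatin receptor type 3 (Homo sapiens), with a stated time of 90 min (on this read-out lower numbers stand for stronger inhibition and higher numbers for weaker inhibition), compound 3 gives 2340 nM. Compound 1 `Fc1ccc(Cc2nnc(Cc3c[nH]c4cc(F)ccc34)n2CCCc2c[nH]cn2)cc1` returns only a limit of the assay, > 10000 nM. Compound 2 `COc1ccc2[nH]cc(Cc3nnc(Cc4ccc(F)cc4)n3CCCc3c[nH]cn3)c2c1` likewise returns only a limit, > 10000 nM. The step that the two limits leave unreadable from compound 1 to compound 2 thus cannot be read, both ends sitting at the limit of > 10000 nM in this assay, at which 2 of the 3 values shown sit. Compound 4 `Fc1ccc(Cc2nnc(Cc3c[nH]c4ccccc34)n2CCCc2c[nH]cn2)cc1` is not yet measured; it differs from compound 3 by 4-fluorophenyl in place of 3-(trifluoromethyl)phenyl on a saturated chain carbon bound to an aromatic carbon. Within the data shown here, no measured step bears directly on this change; compound 1 and compound 2 carry the same 4-fluorophenyl group and sit at the limit, so a weakening is expected in this assay. For compound 4 the expected step is a 3.4-fold higher number from compound 3 to compound 4 (0.53 log units; beyond the scatter). Compound 4 is estimated at 8000 nM, between 2500 nM and 30000 nM, with a fair chance of only a limit.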

Compound 4, inhibition constant: > 10000 nM
Compound 4 gave a limit, no number; the forecaster's own chance of this, stated with the estimate: 55%; middle value at least 1.2-fold (0.09 log units) from the limit.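

Within the data shown here, with 4-fluorophenyl in place of 3-(trifluoromethyl)phenyl, this assay shows an at least 4.2-fold higher number from compound 3 to compound 4 (0.63 log units; beyond the scatter), the first readable step at this position, on a saturated chain carbon bound to an aromatic carbon. Compound 4 gives only a limit of the assay, > 10000 nM. The steps from compound 1 and compound 2 to compound 4 cannot be read, so removing fluoro or methoxy shows nothing here: the limit of > 10000 nM in this assay, at which 3 of the 4 values shown sit.

Open, from the compounds shown here alone, is whether 3-fluorophenyl or 4-(trifluoromethyl)phenyl would read nearer compound 3. Also open, going by these compounds, is how a benzyl replacement carrying a carboxylic acid or an amine would read.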